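The compounds below may be only part of what the source reports. "The series", "measured", "known", "first", "only" and "open" are said of these compounds alone.

Measured so far:
compound 1 `CCC1=C(O)c2c(oc(-c3ccc(Br)cc3)cc2=O)C(CC)(CC)C1=O`: > 48.1 uM (a limit)
compound 2 `CCC1=C(O)c2c(oc(-c3ccc(C)c(C)c3)cc2=O)C(CC)(CC)C1=O`: 35.5 uM

In a functional assay on KB cells (Homo sapiens) for antiproliferative activity, read by sulforhodamine B assay, with a stated time of 3 days (a lower number here means that less compound is needed, a higher number that more compound is needed for the effect), compound 1 gives > 48.1 uM, which is a limit of the assay and not a number. Going by the values given here, compound 2 gives 35.5 uM, the only true number so far. Next comes compound 3 `CCC1=C(O)c2c(oc(-c3ccc(C)c(Cl)c3)cc2=O)C(CC)(CC)C1=O`, which has chloro in place of methyl on an aromatic carbon, ortho to a methyl group and meta to a large group: chloro in place of methyl on an aromatic carbon. This turns 3,4-dimethylphenyl into 3-chloro-4-methylphenyl. Among the compounds with values here, the one measured step that bears on it is an at least 1.3-fold lower number from compound 1 to compound 2 (0.13 log units; that floor lies within the scatter), with 3,4-dimethylphenyl in place of 4-bromophenyl. That step does not clear the scatter, so no change beyond the scatter is expected in this assay, in either direction. The expected step is a 1.1-fold lower number from compound 2 to compound 3 (0.05 log units; within the scatter). For compound 3 the estimated value is 32 uM, with an expected range from 15 uM to 55 uM.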

Compound 3, concentration for half-maximal effect: 39 uM
Compound 3: the middle estimate sits 1.2-fold (0.09 log units) below what was measured; low and high end bracket the measured number.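

In this assay, chloro in place of methyl on an aromatic carbon, ortho to a methyl group and meta to a large group, gives a step with a true number at both ends, which the earlier step lacked: a 1.1-fold higher number from compound 2 to compound 3 (0.04 log units; within the scatter). Methyl and chloro at this position therefore cannot be told apart in this assay. Against compound 1 only a floor can be given, an at least 1.2-fold lower number from compound 1 to compound 3 (0.09 log units; that floor lies within the scatter), and that floor rests on a limit and not on a number: the limit of > 48.1 uM in this assay, at which 1 of the 3 values shown sits.

Still open, as far as these compounds go, is whether a group such as an amine, a carboxylic acid or a longer chain at this position would move the number beyond the scatter. Also open, from the compounds shown here alone, is whether the 4-bromophenyl of compound 1 truly differs from the 3,4-dimethylphenyl and 3-chloro-4-methylphenyl of compound 2 and compound 3.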